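Adding dimethylamino to the acetyl group of compound 1

This account rests on a few compounds, and the source may have more. Where it says the series, first, only, none or still open, it means among the compounds named here.

Among the compounds with values here, in a functional assay on NCI-H460 cells (Homo sapiens) (on this read-out higher numbers stand for an effect only at larger amounts of compound and lower numbers for an effect already at smaller amounts), compound 1 `COc1cc(C2OC(c3ccc(N(C)C)cc3)=NN2C(C)=O)cc(OC)c1OC` gives 0.044 uM, the lower of the two numbers so far. Compound 2 `COc1cc(C2OC(c3ccc(N(C)C)cc3)=NN2C(C)=O)cc(OC)c1OC(C)=O` gives 13 uM. Within the data shown here, the only measured step is a 300-fold higher number from compound 1 to compound 2 (2.47 log units; beyond the scatter), with acetyl in place of methyl on an oxygen on an aromatic ring. Compound 3 `COc1cc(C2OC(c3ccc(N(C)C)cc3)=NN2C(=O)CN(C)C)cc(OC)c1OC` keeps that methyl and differs elsewhere: dimethylamino in place of hydrogen on a saturated chain carbon bound to a carbonyl carbon. The measured step lies at another place and gives no direct measure of this change. Among the measured compounds shown here, it shows only that one change reached a 300-fold higher number from compound 1 to compound 2 (2.47 log units; beyond the scatter). A moderate move toward a higher number in this assay is expected, with wide uncertainty. The estimated step is a 3.4-fold higher number from compound 1 to compound 3 (0.53 log units; beyond the scatter). The expected value for compound 3 is 0.15 uM, with an estimated range of 0.03 uM to 1.5 uM.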

Compound 3, concentration for half-maximal effect: 74 uM
Compound 3: the middle estimate sits 490-fold (2.69 log units) below what was measured; measured number above the stated range.
By their numbers in this assay, from the lowest: compound 1; then compound 2; then compound 3.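

Notes on the series: in this assay, the acetyl group of compound 1 turns out to be a second place where one change moves the number sharply upward, since dimethylamino in place of hydrogen on a saturated chain carbon bound to a carbonyl carbon gives a 1700-fold higher number from compound 1 to compound 3 (3.23 log units; beyond the scatter) and this change leaves the methyl on the aromatic oxygen untouched. The earlier step, a 300-fold higher number from compound 1 to compound 2 (2.47 log units; beyond the scatter) with acetyl in place of that methyl, spoke only for the aromatic oxygen, so compound 1 now stays lowest against single changes at two separate places. No measurement on hand bears on the reason for the new step.

From the compounds shown here alone, it remains open whether any addition on this chain carbon has such an effect or whether it is specific to dimethylamino. A primary amine, a hydroxyl or a single methyl at this carbon, or a longer chain carrying the dimethylamino group, would help separate these readings.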